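The compounds below may be only part of what the source reports. "The series", "measured", "known", "first", "only" and "open" are said of these compounds alone.

Working notes on the series.

Within the data shown here, compound 3 `Cc1ccccc1N1CCN(C2=CC(=O)c3ccccc3C2=O)CC1` gives 5700 nM in a functional assay on DU-145 cells (Homo sapiens) for inhibition, read by MTT assay, with a stated time of 72 h (on this read-out lower numbers stand for stronger inhibition and higher numbers for weaker inhibition), and stands second highest of the three numbers so far. Its nearest neighbour is compound 1 `O=C1C=C(N2CCN(c3ccccc3)CC2)C(=O)c2ccccc21` with 9900 nM; the step of a 1.7-fold lower number from compound 1 to compound 3 (0.24 log units; within the scatter) is within the scatter. Compound 2 `O=C1C=C(N2CCN(c3ccccc3Cl)CC2)C(=O)c2ccccc21` gives 2900 nM, and the step of a 2.0-fold higher number from compound 2 to compound 3 (0.29 log units; within the scatter) also lies within the scatter. Among the measured compounds shown here, the only step beyond the scatter is a 3.4-fold lower number from compound 1 to compound 2 (0.53 log units; beyond the scatter).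

Compound 4 `COc1cccc(N2CCN(C3=CC(=O)c4ccccc4C3=O)CC2)c1` differs from compound 3 by 3-methoxyphenyl in place of 2-methylphenyl on an amine nitrogen in a ring. All three measured steps vary the group on the aromatic ring that sits on the amine nitrogen in a ring, so they bear on this change, but none exchanges a methyl for a methoxy or moves the group to another ring carbon. Two of those steps were within the scatter and one was modest, so in this assay no step beyond the scatter is expected, in either direction. The estimated step is a 1.1-fold higher number from compound 3 to compound 4 (0.02 log units; within the scatter). Compound 4 is therefore expected to give 6000 nM, with a range of 2500 nM to 14000 nM.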

Compound 4, half-maximal inhibitory concentration: 15000 nM
Beside the measured number, compound 4's estimate is 2.5-fold (0.40 log units) below it, and the stated range ends below it.
By their numbers in this assay, from the lowest: compounds 2, 3, 1 and 4 (each within the scatter of the next, the first and the last beyond it).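

In this assay, among these compounds, 3-methoxyphenyl in place of 2-methylphenyl on the amine nitrogen gives a 2.6-fold higher number from compound 3 to compound 4 (0.42 log units; beyond the scatter) and so is the first change at this position to take a step beyond the scatter from the 2-methylphenyl compound. In place of 2-chlorophenyl it gives a 5.2-fold higher number from compound 2 to compound 4 (0.71 log units; beyond the scatter), the largest step in the series. Methoxy in place of hydrogen gives only a 1.5-fold higher number from compound 1 to compound 4 (0.18 log units; within the scatter), so the 3-methoxyphenyl group does not repeat the step seen with chloro in a 3.4-fold lower number from compound 1 to compound 2 (0.53 log units; beyond the scatter). Nothing here accounts for these steps.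

The compounds shown do not separate the effect of the methoxy group from that of its ring position, which 2-methoxyphenyl or 3-chlorophenyl on the same nitrogen would address. On these data alone, how an aromatic amine or a carboxylic acid at this ring would read remains open.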